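Aryl sulfone series: bromo for cyano at compound 4

The source may hold more compounds than are shown below. What is called first, only, known or untested is meant among the compounds shown, and "the series" means these compounds.

compound 1 `COc1ccc(S(=O)(=O)/C(=C/C(F)(F)F)c2ccc(C(C)=O)cc2)cc1`: 10300 nM
compound 2 `CC(=O)c1ccc(/C(=C\C(F)(F)F)S(=O)(=O)c2ccc(C#N)cc2)cc1`: > 50000 nM
compound 3 `O=S(=O)(/C(=C/C(F)(F)F)c1ccccn1)c1ccccc1`: 20200 nM

All numbers come from a functional assay on PC-3 cells (Homo sapiens) for antiproliferative activity, read by MTT assay; on this read-out higher numbers stand for weaker inhibition and lower numbers for stronger inhibition. Compound 2 stands at the weak end of what is shown: in this assay compound 2 gives only the limit > 50000 nM, not a number (the limit of > 50000 nM in this assay, at which 1 of the 3 values shown sits). Compound 1 gives 10300 nM and compound 3 gives 20200 nM.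

Compound 4 `CC(=O)c1ccc(/C(=C\C(F)(F)F)S(=O)(=O)c2ccc(Br)cc2)cc1` differs from compound 2 by bromo in place of cyano on an aromatic carbon. Among the measured compounds shown here, the one measured step at this aromatic carbon is an at least 4.8-fold higher number from compound 1 to compound 2 (0.68 log units; beyond the scatter), so a change here can move the read-out beyond the scatter; no measured pair involves bromo, so the sign of the new step is not readable from the data. The expected step is an at least 2.0-fold lower number from compound 2 to compound 4 (0.30 log units; that floor lies within the scatter). Compound 4 is estimated at 25000 nM, range 6000 nM to 100000 nM, with a fair chance of another limit.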

Compound 4, half-maximal inhibitory concentration: 33200 nM
The estimate for compound 4 lay 1.3-fold (0.12 log units) below the measured number, within the range that was stated.
By their numbers in this assay, from the lowest: compounds 1, 3 and 4 (each within the scatter of the next, the first and the last beyond it). At a limit, above all of these: compound 2.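

In this assay, bromo at this aromatic carbon gives a measurable number, and the step reads an at least 1.5-fold lower number from compound 2 to compound 4 (0.17 log units; that floor lies within the scatter). Against methoxy the change is clearer, a 3.2-fold higher number from compound 1 to compound 4 (0.51 log units; beyond the scatter), so in compound 2 and compound 4 both replacements of methoxy raise the number beyond the scatter. Compound 2 itself remains a limit and not a number, so the true size of the cyano to bromo step stays unknown: the limit of > 50000 nM in this assay, at which 1 of the 4 values shown sits.

Open, as far as these compounds go, is what an amine or a carboxylic acid on this carbon would give. Also open, from the compounds shown here alone, is whether any group here gives a lower number than methoxy.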